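Moving Two Chlorines Around the Pendant Phenyl Ring

A few compounds are considered here, and "the series" means these few. Any claim that something is new, unique, unknown or untested is made for them only; others in the source may bear on it.

For the measured compounds named here, compound 2 `CCCS(=O)(=O)Nc1ccc(F)c(C(=O)c2n[nH]c3ncc(-c4ccc(Cl)cc4Cl)cc23)c1F` gives 22% in an assay for binding affinity to dual specificity mitogen-activated protein kinase kinase 4 (Homo sapiens), read by KINOMEscan, tested at 100 nM (on this read-out lower numbers stand for a stronger effect and higher numbers for a weaker effect at the one concentration tested), the higher of the two numbers measured so far. Compound 1 `CCCS(=O)(=O)Nc1ccc(F)c(C(=O)c2n[nH]c3ncc(-c4ccc(C)cc4)cc23)c1F` gives 5.4% in this assay. Going by the values given here, the only measured step, a number 16.6 percentage points higher from compound 1 to compound 2 (beyond the scatter), shows that swapping the pendant aromatic ring shifts the read-out by a modest amount. Compound 3 `CCCS(=O)(=O)Nc1ccc(F)c(C(=O)c2n[nH]c3ncc(-c4cc(Cl)cc(Cl)c4)cc23)c1F` differs from compound 2 in that same ring: 3,5-dichlorophenyl in place of 2,4-dichlorophenyl on an aromatic carbon. Among the compounds with values here, no measured step shows what rearranging two chlorines on this ring does; the one step at hand compares a methyl-bearing ring with a dichlorinated one and bears on the question only loosely. The step expected from rearranging the chlorines is a number 7 percentage points lower from compound 2 to compound 3 (within the scatter), small and downward, since the only other pendant ring measured gave a lower number. Compound 3 is therefore estimated at 15%, within a broad range from 3% to 50%.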

Compound 3, a percentage reported as activity, at one concentration (the size of the read-out at that concentration, not a potency): 73%
For compound 3 the middle estimate is 58 percentage points below the measured one; the measured number lies above the stated range.
By their numbers in this assay, from the lowest: compound 1; then compound 2; then compound 3.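

Rearranging the two chlorines on the pendant ring, with the same atoms in it, gives a number 51 percentage points higher from compound 2 to compound 3 (beyond the scatter) in this assay and so shows that the read-out at this position depends on where the chlorines sit and not only on which atoms the ring carries. Measured against the 4-methylphenyl ring, the 3,5-dichlorophenyl ring gives a number 67.6 percentage points higher from compound 1 to compound 3 (beyond the scatter) and thus a far wider spread across the pendant rings than the earlier pair showed. Nothing available here accounts for the difference between the two chlorine arrangements.

On these data alone, whether this large step is tied to chlorine itself or would recur with methyl or methoxy groups in the same arrangement remains open. Also open, as far as these compounds go, is how this assay would read for an amine on this ring.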